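The source may report more compounds than this note shows. Statements on the series, on what has been measured and on what is new or still open speak of the compounds shown alone.

Working notes on the series.

Of the compounds shown here, two have been measured so far. Compound 1 `CC1(C)Oc2ccc(C#N)cc2[C@@H](/N=C(\NC#N)Nc2ccc(Cl)cc2)[C@@H]1O` carries a cyanoguanidine bearing a 4-chlorophenyl group on the shared core; in a functional assay (aorta) with Rattus norvegicus as the target (on this read-out higher numbers stand for weaker inhibition and lower numbers for stronger inhibition), compound 1 gives 1800 nM. Compound 2 `CC1(C)Oc2ccc(C#N)cc2[C@@H](N2CCN(c3ccccc3)C2=O)[C@@H]1O` replaces that group with a cyclic urea; in this assay compound 2 gives 23700 nM. On these two numbers compound 1 stands lowest, and the gap to compound 2 lies beyond the usual scatter of the read-out, so the cyanoguanidine of compound 1 is the stronger inhibitor of the pair.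

The next compound, compound 3 `COc1ccc(N/C(=N/[C@@H]2c3cc(C#N)ccc3OC(C)(C)[C@H]2O)NC#N)cc1`, keeps the cyanoguanidine of compound 1 and differs from it in one place: methoxy in place of chloro on an aromatic carbon.

Among the measured compounds shown here, no step between two measured compounds of this kind has been recorded, so the size of the change is not anchored by data here. A small step, either unchanged within the scatter or a modest weakening, is expected for compound 3; the expected step from compound 1 to compound 3 in this assay is a 1.7-fold higher number from compound 1 to compound 3 (0.22 log units; within the scatter).

In this assay compound 3 is estimated at 3000 nM, with a range from 1000 nM to 9000 nM.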

Compound 3, half-maximal inhibitory concentration: 32500 nM
For compound 3 the middle estimate is 11-fold (1.03 log units) below the measured one, and the stated range ends below it.
By their numbers in this assay, from the lowest: compound 1; then compounds 2 and 3 (each within the scatter of the next).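

Among the compounds shown here, the exchange of 4-chlorophenyl to 4-methoxyphenyl on the cyanoguanidine is the first single-place step: in this assay it gives an 18-fold higher number from compound 1 to compound 3 (1.26 log units; beyond the scatter), with the rest of the molecule held constant. The substituent on this aromatic carbon therefore matters to the read-out, and swapping chloro for methoxy there is enough to produce a large weakening, so the number of compound 1 cannot be taken as a general value for any group at this place. For the compounds shown here, nothing measured so far bears on why this step is so large.

With only chloro and methoxy read at this place, the compounds shown leave open whether the weakening follows the entry of methoxy or the departure of chloro; a methyl group, a fluorine or a plain hydrogen on the same aromatic carbon would help to separate these two readings. Also open, on these data alone, is whether the same chloro-to-methoxy exchange carries a step of similar size on a phenyl attached to the cyclic urea of compound 2.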